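The compounds below may be only part of what the source reports. "The series", "measured", "known", "first", "only" and "open" are said of these compounds alone.

Compound 1 `CN(C(=O)NC(=O)c1cccc(C(F)(F)F)c1)c1nc(C(F)(F)F)c(C(=O)N/N=C/c2cccc(C(F)(F)F)c2)s1`: 5.79 ug/mL
Compound 2 `CN(C(=O)NC(=O)c1ccc(C(F)(F)F)cc1)c1nc(C(F)(F)F)c(C(=O)N/N=C/c2cccc(C(F)(F)F)c2)s1`: 7.95 ug/mL

Both compounds were tested in a functional assay on HepG2 cells (Homo sapiens) for inhibition, read by MTT assay, with a stated time of 72 h; a higher number here means a weaker inhibitor, a lower number a stronger inhibitor. Compound 2 gives 7.95 ug/mL there, the highest of the two numbers, while compound 1 gives 5.79 ug/mL; the two lie within the scatter of each other, so they cannot be told apart. Within the data shown here, the only measured step, a 1.4-fold higher number from compound 1 to compound 2 (0.14 log units; within the scatter), comes from exchanging one trifluoromethyl-substituted phenyl for another on a carbonyl carbon, and it stays within the scatter.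

The unmeasured compound 3 `CN(C(=O)NC(=O)c1ccc(Cl)cc1Cl)c1nc(C(F)(F)F)c(C(=O)N/N=C/c2cccc(C(F)(F)F)c2)s1` differs from compound 2 in one place: 2,4-dichlorophenyl in place of 4-(trifluoromethyl)phenyl on a carbonyl carbon. This change sits at the same carbonyl carbon that distinguishes compound 1 from compound 2, and that related step, a 1.4-fold higher number from compound 1 to compound 2 (0.14 log units; within the scatter), was small. Among the measured compounds shown here, no other measured step bears on the new group. For the measured compounds named here, with the one relevant change staying within the scatter, no step beyond the scatter is expected for compound 3 in this assay, in either direction. Compound 3 is therefore estimated at 8 ug/mL, with a range from 4 ug/mL to 16 ug/mL. The expected step is a 1.0-fold higher number from compound 2 to compound 3 (0.00 log units; within the scatter).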

Compound 3, half-maximal inhibitory concentration: 11.2 ug/mL
The estimate for compound 3 lay 1.4-fold (0.15 log units) below the measured number; low and high end bracket the measured number.
By their numbers in this assay, from the lowest: compounds 1, 2 and 3 (each within the scatter of the next).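

This position has now taken more than a shift of one trifluoromethyl group: in this assay the swap to 2,4-dichlorophenyl gives a 1.4-fold higher number from compound 2 to compound 3 (0.15 log units; within the scatter) and stays inside the scatter. Set against the 3-(trifluoromethyl)phenyl group, the same swap gives a 1.9-fold higher number from compound 1 to compound 3 (0.29 log units; within the scatter) and also stays inside the scatter, so no difference can be read among the three compounds, even though the group on this carbonyl carbon now carries chlorine in place of fluorine. No measurement is at hand that would explain this flat result.

Going by these compounds, all three groups at this place are phenyl rings carrying chlorine or trifluoromethyl, so it remains open whether an unsubstituted phenyl, a cyclohexyl ring, a butyl chain, or a phenyl bearing an amine or a carboxylic acid would stay in the same range. On these data alone, the 3-(trifluoromethyl)phenyl group elsewhere on the shared core is the same in all three compounds, so what a change there would do in this assay also remains open.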